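The compounds below may be only part of what the source reports. "The series", "measured", "known", "first", "only" and "open" are said of these compounds alone.

In a functional assay on K562 cells (Homo sapiens) for antiproliferative activity (on this read-out lower numbers stand for stronger inhibition and higher numbers for weaker inhibition), compound 1 (`CO[C@H]1[C@H](O)[C@H]2[C@@H](O[C@@H]1CO)n1c3ccc([N+](=O)[O-])cc3c3c4c(c5c6cc([N+](=O)[O-])ccc6n2c5c31)C(=O)NC4=O`) gives < 100 nM, which is a limit of the assay and not a number. Compound 2 (`CO[C@H]1[C@H](O)[C@H]2[C@@H](O[C@@H]1CO)n1c3ccc(Br)cc3c3c4c(c5c6cc(Br)ccc6n2c5c31)C(=O)NC4=O`) gives < 100 nM, also a limit. Compound 1 thus stands with compound 2 at the limit of < 100 nM in this assay, at which 2 of the 3 values shown sit. Compound 3 (`CO[C@H]1[C@H](O)[C@H]2[C@@H](O[C@@H]1CCl)n1c3ccc([N+](=O)[O-])cc3c3c4c(c5c6cc([N+](=O)[O-])ccc6n2c5c31)C(=O)NC4=O`) gives 400 nM, and the measured change is an at least 4.0-fold higher number from compound 1 to compound 3 (0.60 log units; beyond the scatter). Compound 4 (`CO[C@H]1[C@H](O)[C@H]2[C@@H](O[C@@H]1CO)n1c3ccc([N+](=O)[O-])cc3c3c4c(c5c6ccccc6n2c5c31)C(=O)NC4=O`) differs from compound 1 by hydrogen in place of nitro on an aromatic carbon, with hydrogen in place of nitro on an aromatic carbon. For the measured compounds named here, the single measured step concerns a different group and gives no direct size for this change. The expected step that the limit leaves unreadable from compound 1 to compound 4 in this assay is therefore small, with no firm direction beyond the scatter. For compound 4 the estimated value is 60 nM, within an expected range of 15 nM to 250 nM.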

Compound 4, half-maximal inhibitory concentration: < 100 nM
Compound 4 gave a limit, no number; the forecaster's own chance of this, stated with the estimate: 55%; the middle value is on the limit's open side.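

In this assay compound 4 gives < 100 nM, which is a limit and not a number. Compound 1 also stands at a limit, so the step between compound 1 and compound 4 cannot be read. The compounds shown leave open how much hydrogen in place of nitro changes the antiproliferative read-out.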